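The source may report more compounds than this note shows. Statements on the series, on what has been measured and on what is new or still open speak of the compounds shown alone.

Compound 1 `C=CC(=O)Nc1cc(Nc2ncc3ncn(-c4ccccc4)c3n2)c(OC)cc1N(C)CCN(C)C` and compound 2 `C=CC(=O)Nc1cc(Nc2ncc3ncn(-c4ccccc4Cl)c3n2)c(OC)cc1N(C)CCN(C)C` share one core and differ in a single aromatic substituent. In an ADME assay on HT-29 cells (Homo sapiens) for cytotoxicity, read by MTT assay, with a stated time of 72 h (on this read-out lower numbers stand for stronger inhibition and higher numbers for weaker inhibition), compound 1 gives 8080 nM, and compound 2 gives 11300 nM. The step of a 1.4-fold higher number from compound 1 to compound 2 (0.15 log units; within the scatter) lies within the scatter. Of the two numbers shown, compound 2 carries the higher figure, with compound 1 nearest, and the gap between them is within the scatter. Compound 3 `C=CC(=O)Nc1cc(Nc2ncc3ncn(-c4ccc(F)c(Br)c4)c3n2)c(OC)cc1N(C)CCN(C)C` has not been measured. It differs from compound 2 by 3-bromo-4-fluorophenyl in place of 2-chlorophenyl on an aromatic nitrogen. Among the compounds with values here, only one measured step bears on this change, a 1.4-fold higher number from compound 1 to compound 2 (0.15 log units; within the scatter), which is within the scatter and involves the same ring; no measured step exchanges one substituted phenyl for another. For compound 3 the expected step is therefore a 1.0-fold lower number from compound 2 to compound 3 (0.01 log units; within the scatter), none beyond the scatter. Compound 3 is estimated at 11000 nM, with a range from 5000 nM to 25000 nM.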

Compound 3, half-maximal inhibitory concentration: 3640 nM
Beside the measured number, compound 3's estimate is 3.0-fold (0.48 log units) above it; measured number below the stated range.
By their numbers in this assay, from the lowest: compound 3; then compounds 1 and 2 (each within the scatter of the next).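

In this assay, the group on the aromatic nitrogen can move the number beyond the scatter: 3-bromo-4-fluorophenyl in place of 2-chlorophenyl gives a 3.1-fold lower number from compound 2 to compound 3 (0.49 log units; beyond the scatter), and the same group in place of phenyl gives a 2.2-fold lower number from compound 1 to compound 3 (0.35 log units; beyond the scatter). Both steps are modest, but the earlier exchange at this position, a 1.4-fold higher number from compound 1 to compound 2 (0.15 log units; within the scatter), stayed within the scatter, so the position is not indifferent to its substituents in this assay. Nothing shown gives a reason for the lower number with 3-bromo-4-fluorophenyl.

The bromine and the fluorine enter together, so the compounds shown leave open how much of the step belongs to each, as a 3-bromophenyl or a 4-fluorophenyl group would show. They also leave open whether a methoxy or an amine on the phenyl ring would shift the number in the same direction.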